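Swapping a Fluorine for a Carboxamide on a Shared Core

This account rests on a few compounds, and the source may have more. Where it says the series, first, only, none or still open, it means among the compounds named here.

Compound 1 `COc1ccc(NC(=O)N2CCC(c3c[nH]c4ccc(F)cc34)CC2)cc1N1CCN(C)CC1`: 85 nM
Compound 2 `COc1ccc(NC(=O)N2CCC(c3c[nH]c4cc(F)ccc34)CC2)cc1N1CCN(C)CC1`: 80 nM
Compound 3 `COc1ccc(NC(=O)N2CCN(CCCCc3c[nH]c4ccc(F)cc34)CC2)cc1N1CCN(C)CC1`: 77 nM

In an assay on frontal cortex for binding affinity to 5-hydroxytryptamine receptor 1B (Rattus norvegicus), read by radioligand binding (a lower number here means a stronger inhibitor, a higher number a weaker inhibitor), compound 2 gives 80 nM, which is the second highest of the three numbers; compound 3 gives 77 nM and compound 1 gives 85 nM, and all three lie within the usual scatter of one another, so none can be called stronger or weaker than the rest.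

Compound 4 `COc1ccc(NC(=O)N2CCC(c3c[nH]c4ccc(C(N)=O)cc34)CC2)cc1N1CCN(C)CC1` is not yet measured. It differs from compound 2 in one place: 5-carbamoyl-1H-indol-3-yl in place of 6-fluoro-1H-indol-3-yl on a saturated ring carbon.

Going by the values given here, only one measured step touches this part of the structure. Moving the fluorine from one position to another, a 1.1-fold lower number from compound 1 to compound 2 (0.03 log units; within the scatter), changed nothing beyond the scatter. That step is smaller in kind than the present one, which adds a carbamoyl group with its own hydrogen-bond donors and acceptor, so it gives no firm guide to direction; it only shows that this assay tolerated a change at that group.

With that thin basis, compound 4 is expected to stay close to compound 2, with the expected step being a 1.3-fold lower number from compound 2 to compound 4 (0.12 log units; within the scatter). The estimate for compound 4 in this assay is 60 nM, within a range of 20 nM to 180 nM.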

Compound 4, half-maximal inhibitory concentration: 113 nM
The estimate for compound 4 lay 1.9-fold (0.27 log units) below the measured number, within the range that was stated.
By their numbers in this assay, from the lowest: compounds 3, 2, 1 and 4 (each within the scatter of the next).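

In this assay, replacing 6-fluoro-1H-indol-3-yl with 5-carbamoyl-1H-indol-3-yl gives a 1.4-fold higher number from compound 2 to compound 4 (0.15 log units; within the scatter), and the direct exchange of carbamoyl for fluoro on the same aromatic carbon gives a 1.3-fold higher number from compound 1 to compound 4 (0.12 log units; within the scatter). The earlier compounds shown here showed only that a fluorine could be moved without a change beyond the scatter, whereas these steps show the same for a group with more heavy atoms, a double bond outside the aromatic rings, and more hydrogen-bond donors and acceptors. No accompanying measurement bears on why this exchange leaves the number within the scatter.

The compounds shown leave open whether this tolerance extends to other groups at this position, such as a carboxylic acid, an amine or a nitrile, or whether it would give way with a group of greater size. They also leave open whether placing carbamoyl for fluoro on the core of compound 3 would give a similarly small step, since that core carries only the fluorine here.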